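Adding a Second Benzyloxy Group to Compound 3

The compounds below may be only part of what the source reports. "The series", "measured", "known", "first", "only" and "open" are said of these compounds alone.

Of the compounds shown here, three sharing one core have been tested in a functional assay, read by spectrophotometry, with a stated time of 3 min; on this read-out higher numbers stand for weaker inhibition and lower numbers for stronger inhibition. Compound 1 `O=c1cc(/C=N\O)c2c(OCc3ccccc3)cc(OCc3ccccc3)cc2o1` gives 38700 nM, compound 2 `N/N=C\c1cc(=O)oc2cc(OCc3ccccc3)cc(OCc3ccccc3)c12` gives 363000 nM, and compound 3 `O=c1cc(/C=N\Nc2ccccc2)c2ccc(OCc3ccccc3)cc2o1` gives 13200 nM, the lowest of the three numbers. Among the measured compounds shown here, the only step measured between two compounds differing in one place, a 9.4-fold higher number from compound 1 to compound 2 (0.97 log units; beyond the scatter), concerns a change on the double-bonded nitrogen and not the change considered here. Compound 4 `O=c1cc(/C=N\Nc2ccccc2)c2c(OCc3ccccc3)cc(OCc3ccccc3)cc2o1` differs from compound 3 by benzyloxy in place of hydrogen on an aromatic carbon. For the measured compounds named here, no measured pair isolates this change, so the expectation rests on compound 3 alone. The step of a 1.1-fold higher number from compound 3 to compound 4 (0.06 log units; within the scatter) is expected to stay within the scatter. Compound 4 is therefore estimated at 15000 nM, with a likely range from 5000 nM to 50000 nM.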

Compound 4, half-maximal inhibitory concentration: 40100 nM
Estimate against measurement, compound 4: 2.7-fold (0.43 log units) below; measured number inside the range.
By their numbers in this assay, from the lowest: compound 3; then compounds 1 and 4 (each within the scatter of the next); then compound 2.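

In this assay this aromatic carbon, ortho to a fused ring, does not accept a benzyloxy group in place of hydrogen without cost: the step is a 3.0-fold higher number from compound 3 to compound 4 (0.48 log units; beyond the scatter). With both benzyloxy groups present, phenyl in place of hydrogen on the amine nitrogen still counts, at a 9.1-fold lower number from compound 2 to compound 4 (0.96 log units; beyond the scatter), whereas anilino in place of hydroxy on the double-bonded nitrogen shows no difference beyond the scatter, at a 1.0-fold higher number from compound 1 to compound 4 (0.02 log units; within the scatter). No measurement at hand accounts for these steps.

From the compounds shown here alone, whether methoxy or hydroxy on this same carbon would give a number closer to that of compound 3 or compound 4 remains open.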